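A few compounds are considered here, and "the series" means these few. Any claim that something is new, unique, unknown or untested is made for them only; others in the source may bear on it.

Measured set in a functional assay on the whole organism (Tail, strain ICR) with Mus musculus as the target, in the tail flick test, with a stated time of 150 min, at a dose of 6.25 umol/kg by the oral route; a higher number here means a stronger effect of the compound at the dose given, a lower number a weaker effect:
compound 1 `N=C(N)NCCC[C@H](NC(=O)CN(c1nc(Cl)nc2[nH]cnc12)C1CC1)C(=O)O` gives 5.09%
compound 2 `CC(C)[C@H](NC(=O)CN(c1nc(Cl)nc2[nH]cnc12)C1CC1)C(=O)OCc1ccccc1` gives 3.07%
compound 3 `NCCCC[C@H](NC(=O)CN(c1nc(Cl)nc2[nH]cnc12)C1CC1)C(=O)OCc1ccccc1` gives 4.87%

Compound 3 stands second of the three numbers; the nearest is compound 1, whose value lies above it by a difference within the scatter, and the furthest is compound 2, whose value lies below it by a difference also within the scatter. All three values are low and sit within the scatter of one another, so no order among them can be read.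

The step under consideration leads to compound 4 `NCCCC[C@H](NC(=O)CN(c1nc(Cl)nc2[nH]cnc12)C1CC1)C(=O)O`, which differs from compound 3 by hydrogen in place of benzyl on an oxygen next to a carbonyl group. Within the data shown here, no measured step bears directly on this change. Among the measured compounds shown here, compound 1 carries the same carboxy group with a different side chain and gives a value close to that of compound 3, but no pair in the set differs only in benzyl against hydrogen on that oxygen. For the measured compounds named here, the only measured step, a number 1.8 percentage points higher from compound 2 to compound 3 (within the scatter), concerns a different place and lies within the scatter. Nothing in the set therefore points to a step beyond the scatter in this assay in either direction. The step of a number 0.1 percentage points higher from compound 3 to compound 4 (within the scatter) is expected to stay within the scatter. Compound 4 is estimated at 5%, with a range from 0% to 12%.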

Compound 4, a percentage reported as activity, at one dose (the size of the read-out at that dose, not a potency): 2.82%
Compound 4: middle estimate off by 2.2 percentage points, on the high side; low and high end bracket the measured number.
By their numbers in this assay, from the lowest: compounds 4, 2, 3 and 1 (each within the scatter of the next).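

In this assay, among these compounds, the first direct pair for hydrogen in place of benzyl on an oxygen next to a carbonyl group gives a number 2.1 percentage points lower from compound 3 to compound 4 (within the scatter), so benzyloxycarbonyl to carboxy produces no separable change in this read-out at this single dose and time. Among the compounds shown here, with the carboxy group held constant, the first direct pair at the saturated chain carbon, four bonds along the chain from an amide-type nitrogen and a carbonyl carbon, gives a number 2.3 percentage points lower from compound 1 to compound 4 (within the scatter), so the exchange of the end group at that place cannot be resolved here either. No measurement on hand bears on what lies behind either step.

As far as these compounds go, it remains open whether a methyl ester or an ethyl ester in place of the benzyl ester, or a longer chain in place of the 4-aminobutyl side chain, would give a step beyond the scatter. From the compounds shown here alone, it also remains open whether the compounds would separate at another dose or time, since one dose and one time cannot show how the effect varies with either.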